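One Added Methoxy and Growth Inhibition

The compounds below may be only part of what the source reports. "The series", "measured", "known", "first", "only" and "open" are said of these compounds alone.

Measured in a functional assay on MCF7 cells (Homo sapiens) for inhibition, read by MTT assay, with a stated time of 24 h; a lower number here means a stronger inhibitor of growth, a higher number a weaker inhibitor of growth:
Compound 1 `COc1cc(C(=O)n2c(-c3cn(C)c4ccccc34)nc3ccccc32)cc(OC)c1OC`: 5400 nM
Compound 2 `COc1ccc2c(c1)c(-c1nc3ccccc3n1C(=O)c1ccc(OC)c(OC)c1)cn2C`: 6300 nM

Compound 2 at 6300 nM lies within the usual scatter of compound 1, so the two cannot be ranked. Compound 3 `COc1ccc2c(c1)c(-c1nc3ccccc3n1C(=O)c1cc(OC)c(OC)c(OC)c1)cn2C` differs from compound 2 in one place: methoxy in place of hydrogen on an aromatic carbon. For the measured compounds named here, no measured pair shows this change alone. Compound 3 shares structural features with compound 1 at 5400 nM and compound 2 at 6300 nM, so only a small shift toward stronger inhibition in this assay is expected. The estimated change is a 1.6-fold lower number from compound 2 to compound 3 (0.20 log units; within the scatter), within the scatter. The expected value for compound 3 is 4000 nM, with an estimated range of 1300 nM to 9000 nM.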

Compound 3, concentration for 50% growth inhibition: 5100 nM
Compound 3: the middle estimate sits 1.3-fold (0.11 log units) below what was measured; the measured number falls inside the stated range.
By their numbers in this assay, from the lowest: compounds 3, 1 and 2 (each within the scatter of the next).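

In this assay a methoxy group added on an aromatic carbon, ortho to a methoxy group, gives a 1.2-fold lower number from compound 2 to compound 3 (0.09 log units; within the scatter) and the same swap at another place gives a 1.1-fold lower number from compound 1 to compound 3 (0.02 log units; within the scatter) as well. For the compounds shown here, this is the first pair to show the change alone, and the added methoxy brings no change that can be told from the scatter. Nothing measured here gives a reason for this result.

As far as these compounds go, whether an amine, a carboxylic acid or a longer chain such as butoxy at this carbon would also stay within the scatter remains open.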